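The compounds below may be only part of what the source reports. "The series", "measured", "known", "first", "only" and "open" are said of these compounds alone.

In an ADME assay on the whole organism (strain Sprague-Dawley) for pharmacokinetics, with Rattus norvegicus as the target, at a dose of 5 mg/kg by the oral route (on this read-out lower numbers stand for lower exposure and higher numbers for higher exposure at the dose given), compound 1 `O=S(=O)(Nc1ccc(Oc2cnc3ccccc3c2)c(Cl)c1)c1ccc(Cl)cc1Cl` reaches 11000 nM, compound 2 `O=S(=O)(Nc1ccc(Oc2cnc3ccccc3c2)c(F)c1)c1ccc(Cl)cc1Cl` reaches 4800 nM and compound 3 `O=S(=O)(Nc1cc(Cl)c(Oc2cnc3ccccc3c2)c(Cl)c1)c1ccc(C(F)(F)F)cc1Cl` reaches 8500 nM on the same measure. Compound 2 sits within the usual scatter of compound 3 and beyond the scatter from compound 1.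

The next compound, compound 4 `CC(=O)c1cc(NS(=O)(=O)c2ccc(Cl)cc2Cl)ccc1Oc1cnc2ccccc2c1`, differs from compound 2 by having acetyl in place of fluoro on an aromatic carbon. Among the compounds with values here, only one measured step changes a single group at that place (a 2.3-fold lower number from compound 1 to compound 2 (0.36 log units; beyond the scatter)), and it was modest. Within the data shown here, that step exchanges one small group for another, so it is only a loose guide to acetyl, for which no measured example exists. Compound 3 differs from compound 1 in more than one place and offers no direct comparison. From the compounds shown here alone, no change beyond the scatter is therefore expected, and the direction remains open, with a slight fall as the cautious guess. The expected change (a 1.4-fold lower number from compound 2 to compound 4 (0.14 log units; within the scatter)) is small beside the uncertainty. Compound 4 is expected at 3500 nM with a range from 1000 nM to 10000 nM as the estimate.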

Compound 4, maximal plasma concentration: 920 nM
Beside the measured number, compound 4's estimate is 3.8-fold (0.58 log units) above it; measured number below the stated range.
By their numbers in this assay, from the lowest: compound 4; then compounds 2, 3 and 1 (each within the scatter of the next, the first and the last beyond it).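

In this assay, the group on this aromatic carbon, ortho to a large group and meta to a large group, can move the read-out well beyond the scatter: acetyl gives a 5.2-fold lower number from compound 2 to compound 4 (0.72 log units; beyond the scatter) and, against chloro, a 12-fold lower number from compound 1 to compound 4 (1.08 log units; beyond the scatter) in a large step. Within the data shown here, the only earlier change here, a 2.3-fold lower number from compound 1 to compound 2 (0.36 log units; beyond the scatter), was modest and swapped one small group for another, whereas acetyl brings more heavy atoms and a hydrogen-bond acceptor, and among compounds 1, 2 and 4 it gives the lowest number. Nothing measured here explains this fall.

From the compounds shown here alone, it remains open whether the fall follows the carbonyl or simply the greater size of acetyl. A nitrile, a methoxy group or an amide on the same carbon would help to separate these two readings.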